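The compounds below may be only part of what the source reports. "The series", "measured", "known", "first", "only" and "open" are said of these compounds alone.

The series shares a single core, and the step considered here runs from compound 1, `CNc1ncc(C#Cc2ccc(C)cc2)cn1`, to compound 4, `CCNc1ncc(C#Cc2ccc(C)cc2)cn1`, which has not yet been measured.

In an assay on HEK293 cells for positive allosteric modulation of metabotropic glutamate receptor 5 (Rattus norvegicus) (on this read-out lower numbers stand for an effect already at smaller amounts and higher numbers for an effect only at larger amounts of compound), compound 1 gives 704000 nM. That is the highest of the two numbers reported. The nearest measured neighbour is compound 3, `CNc1ncc(C#Cc2cccc(C)c2)cn1`, which in this assay gives 21100 nM, a far lower number, well beyond the usual scatter. Compound 2, `COc1ncc(C#Cc2ccccc2)cn1`, is described in this assay as "not active" (no number reported), and no number was reported for it.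

Compound 4 differs from compound 1 in one place: methyl in place of hydrogen on a saturated chain carbon bound to a nitrogen on an aromatic ring. For the measured compounds named here, no measured pair in this set shows this particular change, so nothing here tells how the half-maximal effective concentration answers to it. Given that, a step from compound 1 to compound 4 is expected to stay within the scatter, in either direction, and the estimate for the step is a 1.2-fold lower number from compound 1 to compound 4 (0.07 log units; within the scatter). Compound 4 is therefore expected to give about 600000 nM in this assay, with a range from 150000 nM to 2500000 nM, and a real chance that only a limit rather than a number is reported.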

Compound 4, half-maximal effective concentration: "not active" (no number reported)
Nothing numeric was reported for compound 4, and the estimate cannot be compared.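

In this assay, for the compounds shown here, compound 4 is reported as "not active" without a number, so no step from compound 1 can be read. Nothing available bears on this result. The compounds shown leave open how far the change from methylamino to ethylamino shifts the half-maximal effective concentration.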